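The source may report more compounds than this note shows. Statements on the series, on what has been measured and on what is new or still open speak of the compounds shown alone.

Measured so far:
compound 1 `CC(=O)N1CCC(c2ccc3c(c2)oc(=O)n3C(=O)NCCCCc2ccccc2)CC1`: 64 nM
compound 2 `CC(C)CNC(=O)n1c(=O)oc2c(C3CCN(C)CC3)cccc21`: 535 nM
compound 3 `CN1CCc2oc(=O)n(C(=O)NCCCCc3ccccc3)c2C1`: 516 nM

In an assay on HEK293 cells for inhibition of acid ceramidase (Homo sapiens), read by fluorescence, with stated times of 10 min and 3 h (a lower number here means a stronger inhibitor, a higher number a weaker inhibitor), compound 1 gives the lowest of the three numbers; compound 3 is nearest to it and compound 2 furthest from it, and both gaps lie beyond the scatter. Compound 4 `CCN1CCN(c2ccc3c(c2)oc(=O)n3C(=O)NCCCCc2ccccc2)CC1` is not yet measured. It differs from compound 1 in one place: 4-ethylpiperazin-1-yl in place of 1-acetylpiperidin-4-yl on an aromatic carbon. Among the measured compounds shown here, compounds 2 and 3 each differ from compound 1 in several places at once, so no single-change step between measured compounds is available to set the size of this one. A small step is expected from compound 1 to compound 4, toward a higher number, about a 1.6-fold higher number from compound 1 to compound 4 (0.19 log units; within the scatter), not clearly beyond the scatter. Compound 4 is estimated at 100 nM, with a range from 30 nM to 350 nM.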

Compound 4, half-maximal inhibitory concentration: 56 nM
Estimate against measurement, compound 4: 1.8-fold (0.25 log units) above, and the stated range covers the measured number.
By their numbers in this assay, from the lowest: compounds 4 and 1 (each within the scatter of the next); then compounds 3 and 2 (each within the scatter of the next).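

At this aromatic carbon, 4-ethylpiperazin-1-yl in place of 1-acetylpiperidin-4-yl gives a 1.1-fold lower number from compound 1 to compound 4 (0.06 log units; within the scatter) in this assay, so this assay does not separate the two groups. The carbonyl of the acetyl group is therefore not required at this position for a number of this size, at least with the shared core and butyl-phenyl side chain of compound 1 and compound 4. No measurement at hand bears on why the two groups read alike.

Open, on these data alone, is whether an open-chain amine such as dimethylamino, or a carboxylic acid, would hold up at this carbon. A longer chain in place of the ethyl group on the piperazine is equally untested here.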